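The source may hold more compounds than are shown below. What is called first, only, known or untested is meant among the compounds shown, and "the series" means these compounds.

Compound 3 `Oc1cccc(-c2cc(-c3cccs3)nc(-c3ccccc3Cl)c2)c1` sits lowest of the three numbers in an assay on isolated protein for inhibition of DNA topoisomerase 1 (Homo sapiens), with a stated time of 30 min, tested at 100 uM; a higher number here means a stronger effect of the compound at the concentration tested, a lower number a weaker effect: compound 3 gives 2.7%, while compound 2 `Oc1cccc(-c2cc(-c3cccc(Cl)c3)nc(-c3ccco3)c2)c1` gives 5.5%, within the scatter of compound 3, and compound 1 `Oc1cccc(-c2cc(-c3cccnc3)nc(-c3cccc(Cl)c3)c2)c1` gives 27.6%, beyond it. The one single-point step shown, a number 22.1 percentage points lower from compound 1 to compound 2 (beyond the scatter), concerns a change elsewhere on the shared core and does not bear on the step to compound 4 `Oc1cccc(-c2cc(-c3cccc(Cl)c3)nc(-c3cccs3)c2)c1`, which differs from compound 3 by 3-chlorophenyl in place of 2-chlorophenyl on an aromatic carbon. Among the measured compounds shown here, no measured pair isolates this change; compound 2, which also carries the 3-chlorophenyl group, and compound 3 both lie low, within the scatter of each other. Compound 4 is therefore expected near that floor, with a number 5.3 percentage points higher from compound 3 to compound 4 (within the scatter) not beyond the scatter, estimated at 8% with a range of 0% to 25%.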

Compound 4, a percentage reported as inhibition, at one concentration (the size of the read-out at that concentration, not a potency): 7.6%
Estimate against measurement, compound 4: 0.4 percentage points above; the range from low to high includes it.
By their numbers in this assay, from the lowest: compounds 3, 2 and 4 (each within the scatter of the next); then compound 1.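

In this assay, the change to 3-chlorophenyl from 2-chlorophenyl on the carbon next to the ring nitrogen does not separate the two chlorophenyl groups (a number 4.9 percentage points higher from compound 3 to compound 4 (within the scatter)). With 3-chlorophenyl in place, thiophen-2-yl and furan-2-yl are likewise not separated (a number 2.1 percentage points higher from compound 2 to compound 4 (within the scatter)), whereas pyridin-3-yl stands apart from thiophen-2-yl (a number 20 percentage points lower from compound 1 to compound 4 (beyond the scatter)). Nothing available explains these steps.

Open, as far as these compounds go, is whether pyridin-3-yl keeps this distance alongside 2-chlorophenyl. Also open, from the compounds shown here alone, is how an amine or a carboxylic acid in place of the chlorine would read here.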